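Replacing 3,5-dimethoxyphenyl with phenyl in compound 2

A few compounds are considered here, and "the series" means these few. Any claim that something is new, unique, unknown or untested is made for them only; others in the source may bear on it.

In a functional assay on SW480 cells (Homo sapiens) for antiproliferative activity, read by MTT assay, with a stated time of 72 h (a lower number here means a stronger inhibitor, a higher number a weaker inhibitor), compound 2 `COc1cc(NC(=O)C(=O)[C@H](CC(C)C)NC(=O)[C@H](CC(C)C)NC(=O)[C@H](CC(C)C)NC(=O)OCc2ccccc2)cc(OC)c1` gives 72.6 nM, level within the scatter with compound 1 `CCc1cccc(NC(=O)C(=O)[C@H](CC(C)C)NC(=O)[C@H](CC(C)C)NC(=O)[C@H](CC(C)C)NC(=O)OCc2ccccc2)c1` at 82.9 nM. Compound 3 `CC(C)C[C@H](NC(=O)OCc1ccccc1)C(=O)N[C@@H](CC(C)C)C(=O)N[C@@H](CC(C)C)C(=O)C(=O)Nc1ccccc1` carries phenyl in place of 3,5-dimethoxyphenyl on an amide-type nitrogen. Within the data shown here, the one measured step at that nitrogen, a 1.1-fold lower number from compound 1 to compound 2 (0.06 log units; within the scatter), stays within the scatter, although no measured compound carries phenyl there. No step beyond the scatter is therefore expected in this assay, in either direction. The expected step is a 1.1-fold higher number from compound 2 to compound 3 (0.04 log units; within the scatter). Compound 3 is estimated at 80 nM, with an expected range of 35 nM to 190 nM.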

Compound 3, half-maximal inhibitory concentration: 106 nM
The estimate for compound 3 lay 1.3-fold (0.12 log units) below the measured number; low and high end bracket the measured number.
By their numbers in this assay, from the lowest: compounds 2, 1 and 3 (each within the scatter of the next).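

In this assay, the unsubstituted phenyl on the amide-type nitrogen gives a 1.5-fold higher number from compound 2 to compound 3 (0.16 log units; within the scatter) and a 1.3-fold higher number from compound 1 to compound 3 (0.11 log units; within the scatter) as its two steps, and both stay within the scatter. Removing the two methoxy groups of 3,5-dimethoxyphenyl or the ethyl of 3-ethylphenyl therefore leaves the number level, so across these three compounds the ring substituents shown make no readable difference. Nothing available explains this level result.

The compounds shown leave open whether an amine or a carboxylic acid on this ring would move the number beyond the scatter.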